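The compounds below may be only part of what the source reports. "The series", "measured", "known", "first", "only" and "open" are said of these compounds alone.

Measured compounds:
compound 1, `COc1ccc(OCC(=O)Nc2cccc(NC(=O)c3ccc(N(C)C)cc3)c2)cc1F`, 1820 nM
compound 2, `CN(C)c1ccc(C(=O)Nc2cccc(NC(=O)COc3ccc4occc(=O)c4c3)c2)cc1`, > 10000 nM
compound 3, `CCCC(=O)Nc1cccc(NC(=O)COc2ccc3c(=O)ccoc3c2)c1`, 1430 nM

In an assay on isolated protein for inhibition of Rho-associated protein kinase 1 (Homo sapiens), read by scintillation counting, radiometric assay and 33P incorporation, with a stated time of 40 min, in the presence of a further agent that is not named here (a lower number here means a stronger inhibitor, a higher number a weaker inhibitor), compound 3 gives 1430 nM, the lowest of the two numbers shown; compound 1 sits nearest with a value of 1820 nM, and the gap between compound 3 and compound 1 is within the scatter. For compound 2 this assay reports only a limit, > 10000 nM, and no number. Among the measured compounds shown here, the one measured step, an at least 5.4-fold higher number from compound 1 to compound 2 (0.73 log units; beyond the scatter), changes the aryl ether end of the shared core, not the amide end, so it does not bear directly on the present change; it does show that attaching the chromenone ether can push a compound to the limit of > 10000 nM in this assay, at which 1 of the 3 values shown sits.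

The unmeasured compound 4 is `Cc1ccc(C(=O)Nc2cccc(NC(=O)COc3ccc4c(=O)ccoc4c3)c2)cc1`. It differs from compound 3 in one place: 4-methylphenyl in place of propyl on a carbonyl carbon. Compound 2 also carries an aromatic amide together with a chromenone ether, and compound 1 with an aromatic amide sits within the scatter of compound 3, so the picture is mixed. Compound 4 is therefore expected to come out somewhat weaker than compound 3, with a step of a 2.1-fold higher number from compound 3 to compound 4 (0.32 log units; beyond the scatter) in this assay, and to give an estimated 3000 nM, within a range from 800 nM to 15000 nM.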

Compound 4, half-maximal inhibitory concentration: 183 nM
Compound 4: the middle estimate sits 16-fold (1.21 log units) above what was measured, and the stated range ends above it.
By their numbers in this assay, from the lowest: compound 4; then compounds 3 and 1 (each within the scatter of the next). At a limit, above all of these: compound 2.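

Among the compounds shown here, at this position, on a carbonyl carbon whose other neighbours are an amide-type nitrogen, the earlier compounds offered no measured change; in this assay putting 4-methylphenyl in place of propyl gives a 7.8-fold lower number from compound 3 to compound 4 (0.89 log units; beyond the scatter) and so shows that this end of the shared core can carry an aromatic ring and still yield the stronger inhibitor of the pair. For the compounds shown here, the only earlier step changed the aryl ether end, so this is the first sign that the amide end also moves the number, and that a large step can be had there with the chromenone ether kept in place. Nothing measured here gives a reason for this step.

As far as these compounds go, whether the step comes from the ring itself or needs its methyl stays open, since one pair cannot separate the two. From the compounds shown here alone, how a plain phenyl, a saturated cyclohexyl or a ring bearing an amine or a carboxylic acid would read at this position is also open, as is whether 4-methylphenyl would give a similar step with a different ether end.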